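Swapping the bicyclic group on a side-chain carbon

This account rests on a few compounds, and the source may have more. Where it says the series, first, only, none or still open, it means among the compounds named here.

- Compound 1 `O=C(O)CCC/C=C1\CC2C[C@@H](O)[C@H](/C=C/[C@@H](O)c3ccc4c(c3)OCCO4)C2C1`: > 0.3 mg/kg
- Compound 2 `O=C(O)CCC/C=C1\CC2C[C@@H](O)[C@H](/C=C/[C@@H](O)CC3COc4ccccc4O3)C2C1`: > 0.3 mg/kg
- Compound 3 `CC1([C@H](O)/C=C/[C@@H]2C3C/C(=C/CCCC(=O)O)CC3C[C@H]2O)COc2ccccc2O1`: 0.0142 mg/kg

In a functional assay on the whole organism (stomach) for inhibition, with Rattus norvegicus as the target (a lower number here means that less compound is needed, a higher number that more compound is needed for the effect), compound 1 gives > 0.3 mg/kg, which is a limit and not a number. Compound 2 gives > 0.3 mg/kg, which is also a limit. Compound 3, by contrast, has a true measured value of 0.0142 mg/kg.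

Compound 4 `O=C(O)CCC/C=C1\CC2C[C@@H](O)[C@H](/C=C/[C@@H](O)C3Cc4ccccc4C3)C2C1` has not yet been measured. It differs from compound 1 as follows: 2,3-dihydro-1H-inden-2-yl in place of 2,3-dihydro-1,4-benzodioxin-6-yl on a saturated chain carbon bound to a double-bonded chain carbon and an oxygen on a saturated carbon. In words, 2,3-dihydro-1H-inden-2-yl stands in place of 2,3-dihydro-1,4-benzodioxin-6-yl on a saturated chain carbon bound to a double-bonded chain carbon and an oxygen on a saturated carbon.

Going by the values given here, no measured pair isolates this kind of change, so any forecast is loose. Compound 3 at 0.0142 mg/kg shows that the shared core can reach a low dose, so a move toward less compound is expected. The expected size is an at least 2.5-fold lower number from compound 1 to compound 4 (0.39 log units; beyond the scatter). For compound 4 the estimated value is 0.12 mg/kg, with an expected range of 0.02 mg/kg to 1 mg/kg.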

Compound 4, dose for half-maximal effect: 0.0562 mg/kg
For compound 4 the middle estimate is 2.1-fold (0.33 log units) above the measured one, and the stated range covers the measured number.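

In this assay, going by these compounds alone, placing 2,3-dihydro-1H-inden-2-yl in place of 2,3-dihydro-1,4-benzodioxin-6-yl on this saturated chain carbon gives an at least 5.3-fold lower number from compound 1 to compound 4 (0.72 log units; beyond the scatter), which is the first readable step in this set. The group at this place can therefore decide whether a compound on the shared core gives a measured dose rather than a limit. The true size of the step stays open because compound 1 sits at a limit and not at a number: the limit of > 0.3 mg/kg in this assay, at which 2 of the 4 values shown sit.

The change swaps a ring with 2 hetero atoms for a carbon-only ring and also alters ring size, so this one step cannot show which of these differences counts. Going by these compounds, a phenyl or 2,3-dihydro-1H-inden-5-yl group at this place would help to separate them, and how either compares remains open.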